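Amino for hydroxy: working notes on the series

The compounds below may be only part of what the source reports. "The series", "measured", "known", "first", "only" and "open" are said of these compounds alone.

In a functional assay on KB cells (Homo sapiens) for antiproliferative activity, read by MTT assay, with a stated time of 72 h (a lower number here means a stronger inhibitor, a higher number a weaker inhibitor), compound 1 `COc1ccc(-c2ssc(=S)c2-c2cc(OC)c(OC)c(OC)c2)cc1O` reads 435 nM and compound 2 `COc1ccc(-c2c(-c3cc(OC)c(OC)c(OC)c3)ssc2=S)cc1[N+](=O)[O-]` reads 38200 nM while compound 3 `COc1ccc(-c2ssc(=O)c2-c2cc(OC)c(OC)c(OC)c2)cc1O` reads 460 nM and so lies within the scatter of compound 1 and far below compound 2. The next entry is compound 4 `COc1ccc(-c2ssc(=O)c2-c2cc(OC)c(OC)c(OC)c2)cc1N`, which has amino in place of hydroxy on an aromatic carbon, ortho to a methoxy group (counted change: amino in place of hydroxy on an aromatic carbon). Within the data shown here, no measured pair isolates this exchange, so the expectation rests on little. An expected step of a 1.5-fold lower number from compound 3 to compound 4 (0.19 log units; within the scatter) would be small, toward a lower number and within the scatter. In this assay the estimate for compound 4 is 300 nM and the expected range runs from 60 nM to 1500 nM for now.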

Compound 4, half-maximal inhibitory concentration: 60 nM
For compound 4 the middle estimate is 5.0-fold (0.70 log units) above the measured one, within the range that was stated.
By their numbers in this assay, from the lowest: compound 4; then compounds 1 and 3 (each within the scatter of the next); then compound 2.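

In this assay, among these compounds, 3-amino-4-methoxyphenyl in place of 3-hydroxy-4-methoxyphenyl gives a step beyond the scatter (a 7.7-fold lower number from compound 3 to compound 4 (0.88 log units; beyond the scatter)), the only single-place comparison so far. This position therefore responds to the exchange, although hydroxy and amino carry the same counts of heavy atoms, donors and acceptors. Nothing at hand explains the step. As far as these compounds go, whether the same exchange would give a similar step on the core of compound 1 remains open. Also open, from the compounds shown here alone, is how an acetamide or a dimethylamino group would read at this position.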